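Methyl in place of hydrogen: cytotoxicity notes on the series

The source may report more compounds than this note shows. Statements on the series, on what has been measured and on what is new or still open speak of the compounds shown alone.

Compound 1 `COc1ccc(CSc2nc(Cc3ccc(-c4ccccc4)cc3)c(C)c(=O)[nH]2)cc1` serves as the reference for the first pair. In an ADME assay on MT4 cells (Homo sapiens) for cytotoxicity, read by MTT assay (a higher number here means that more compound is tolerated, a lower number that less compound is tolerated), compound 1 gives 100000 nM. Compound 3 `CCc1c(Cc2ccc(-c3ccccc3)cc2)nc(SCc2ccc(OC)cc2)[nH]c1=O` differs from it by the change (methyl in place of hydrogen on a saturated chain carbon bound to an aromatic carbon). In this assay compound 3 gives 194000 nM. The measured step is a 1.9-fold higher number from compound 1 to compound 3 (0.29 log units; within the scatter), so the two values are not told apart by this read-out.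

Compound 2 `COc1ccc(CSc2nc(Cc3cc(C(F)(F)F)cc(C(F)(F)F)c3)c(C)c(=O)[nH]2)cc1` belongs to the second pair; how its core differs from the core of compound 1 is not broken down here. In this assay compound 2 yields no number but only a limit, > 256000 nM. This is the limit of > 256000 nM in this assay, at which 1 of the 3 values shown sits.

Compound 4 `CCc1c(Cc2cc(C(F)(F)F)cc(C(F)(F)F)c2)nc(SCc2ccc(OC)cc2)[nH]c1=O` is the not yet measured partner of compound 2 and carries the change (methyl in place of hydrogen on a saturated chain carbon bound to an aromatic carbon), the same kind of change, at the same place, as that between compound 1 and compound 3.

For the measured compounds named here, the one measured instance of this change, a 1.9-fold higher number from compound 1 to compound 3 (0.29 log units; within the scatter), stayed within the scatter, so the step from compound 2 to compound 4 is expected to be equally flat, a number no higher from compound 2 to compound 4 (the limit leaves the size open). Compound 2 already sits at a limit in this assay, > 256000 nM, so a limit rather than a number is the likelier outcome for compound 4 as well. Compound 4 is expected at about 256000 nM, with a range from 150000 nM to 450000 nM.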

Compound 4, half-maximal cytotoxic concentration: > 249000 nM
Compound 4 was reported as a limit; the forecaster's own chance of this, stated with the estimate: 70%; the middle value is on the limit's open side.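

In this assay compound 4 gives only a limit, > 249000 nM. Compound 2 also gives only a limit, > 256000 nM. With two limits, the step between compound 2 and compound 4 cannot be read. The compounds shown leave open what number either compound would reach in this assay, and so whether methyl in place of hydrogen changes the tolerated concentration in this pair.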